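The source may report more compounds than this note shows. Statements on the series, on what has been measured and on what is new or still open speak of the compounds shown alone.

Compound 1 `O=C(CCCCC(S)CCS)Nc1ccccc1`: 4.3%
Compound 2 `O=C(CCCCC(CCSC(=O)c1ccccc1)SC(=O)c1ccccc1)Nc1ccccc1Cl`: 14.4%

For the measured compounds named here, in a functional assay on NCI-H460 cells (Homo sapiens) for inhibition, read by MTT assay, with a stated time of 24 h, tested at 1 ug/mL (a higher number here means more inhibition of growth at the concentration tested, a lower number less inhibition of growth), compound 2 gives 14.4%, the higher of the two numbers so far. Compound 1 gives 4.3%, and this gap lies beyond the scatter. The two compounds differ in more than one place, so their gap says nothing direct about a single change.

Compound 3 `O=C(CCCCC(CCSC(=O)c1ccccc1)SC(=O)c1ccccc1)Nc1ccc(Cl)cc1` keeps the core of compound 2 and has the same atoms, joined differently: 4-chlorophenyl in place of 2-chlorophenyl on an amide-type nitrogen. In words, 4-chlorophenyl stands in place of 2-chlorophenyl on an amide-type nitrogen. Going by the values given here, no measured pair shows this change, so no direction can be argued from the data, and no shift beyond the scatter is expected in this assay. The expected change is small: a number 0.6 percentage points higher from compound 2 to compound 3 (within the scatter). For compound 3 the estimated value is 15%, with an expected range from 4% to 30%.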

Compound 3, percent growth inhibition at one concentration: 9.8%
Beside the measured number, compound 3's estimate is 5.2 percentage points above it, and the stated range covers the measured number.
By their numbers in this assay, from the lowest: compounds 1, 3 and 2 (each within the scatter of the next, the first and the last beyond it).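

In this assay, 4-chlorophenyl in place of 2-chlorophenyl on an amide-type nitrogen gives a number 4.6 percentage points lower from compound 2 to compound 3 (within the scatter). For the compounds shown here, this is the first step in the set that changes a single place, and it shows that this assay, at the one concentration tested, does not distinguish these two chlorophenyl groups on that nitrogen. No available evidence bears on this result.

The compounds shown leave open whether any other group on the amide-type nitrogen, such as a pyridine ring or a phenyl ring carrying a carboxylic acid, would move the number beyond the scatter. Going by these compounds alone, they also leave open what the benzoyl groups contribute, since compound 1 differs from compound 2 and compound 3 in more than one place and no single step isolates them.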